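Quinoline Carboxamide Analogues: Replacing the Pendant Aryl Group

The source may hold more compounds than are shown below. What is called first, only, known or untested is meant among the compounds shown, and "the series" means these compounds.

The series shares a common core and differs in the aryl group attached to it. Compound 1 `COc1cccc(-c2cc(C(=O)Nc3ccc(Oc4ccnc5cc(OCCCN6CCCCC6)c(OC)cc45)c(F)c3)c3ccccc3n2)c1` gives 380 nM in a functional assay on SMMC-7721 cells (Homo sapiens) for cytotoxicity, read by MTT assay, with a stated time of 72 h; a lower number here means a stronger inhibitor, a higher number a weaker inhibitor. Compound 2 `COc1cc2c(Oc3ccc(NC(=O)c4cc(-c5ccc(F)cc5)nc5ccccc45)cc3F)ccnc2cc1OCCCN1CCCCC1` gives 74 nM in this assay. Within the data shown here, the step of a 5.1-fold lower number from compound 1 to compound 2 (0.71 log units; beyond the scatter) is the only measured step. Compound 3 `COc1cc2c(Oc3ccc(NC(=O)c4cc(-c5cccc(Cl)c5)nc5ccccc45)cc3F)ccnc2cc1OCCCN1CCC(C)CC1` gives 80 nM, a number close to that of compound 2 and well clear of that of compound 1. Compound 4 `COc1cc2c(Oc3ccc(NC(=O)c4cc(-c5ccc(C)cc5)nc5ccccc45)cc3F)ccnc2cc1OCCCN1CCC(C)CC1` differs from compound 3 by 4-methylphenyl in place of 3-chlorophenyl on an aromatic carbon. Among the measured compounds shown here, the only measured step concerns a different aryl exchange, so it bears on the new one only loosely; no step beyond the scatter is expected for a 1.1-fold higher number from compound 3 to compound 4 (0.05 log units; within the scatter). Compound 4 is therefore expected to give about 90 nM, between 35 nM and 250 nM.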

Compound 4, half-maximal inhibitory concentration: 1260 nM
Estimate against measurement, compound 4: 14-fold (1.15 log units) below; the measured number lies above the stated range.
By their numbers in this assay, from the lowest: compounds 2 and 3 (each within the scatter of the next); then compound 1; then compound 4.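

In this assay, a 16-fold higher number from compound 3 to compound 4 (1.20 log units; beyond the scatter) shows that the aromatic carbon next to the ring nitrogen can respond strongly to an exchange between two aryl groups with equal heavy-atom counts and no hydrogen-bond donors or acceptors. The earlier step, a 5.1-fold lower number from compound 1 to compound 2 (0.71 log units; beyond the scatter), involved a different pair of groups and ran in the opposite direction. Nothing available accounts for the rise.

On these data alone, whether the chlorine-to-methyl exchange or the shift in substituent position carries the step remains open. On the core of compound 3, 4-chlorophenyl and 3-methylphenyl would separate the two.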